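The compounds below may be only part of what the source reports. "The series", "measured", "known", "first", "only" and "open" are said of these compounds alone.

Measured so far:
- Compound 1, `CCc1cccc(NC(=O)CSc2nc(Nc3ccccc3)c3ccccc3n2)c1`: 12400 nM in a functional assay on MDA-MB-231 cells (Homo sapiens) for inhibition, read by MTT assay, with a stated time of 72 h; on this read-out lower numbers stand for stronger inhibition and higher numbers for weaker inhibition
- Compound 2, `C=CC(=O)Nc1cccc(NC(=O)CSc2nc(Nc3ccccc3Br)c3ccccc3n2)c1`: 15200 nM in this assay

Only these two compounds have numbers in this assay. Among the compounds with values here, compound 2 gives 15200 nM and compound 1 gives 12400 nM; the two values sit within the scatter of each other, so neither can be called stronger or weaker than the other, and no step between them is treated as a real difference. Within the data shown here, compound 2 therefore stands on a par with its only neighbour.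

The step under study leads to compound 3, `C=CC(=O)Nc1cccc(NC(=O)CSc2nc(Nc3cccc(Br)c3)c3ccccc3n2)c1`. The change from compound 2 is 3-bromophenyl in place of 2-bromophenyl on a nitrogen on an aromatic ring; compound 3 keeps every atom of compound 2 and only moves the bromine to another position of the same ring. Among the measured compounds shown here, no measured pair in this set shows what such a move does in this assay.

With nothing in the data pointing one way, the expected step of a 1.2-fold lower number from compound 2 to compound 3 (0.07 log units; within the scatter) is small, in no fixed direction, and not beyond the scatter. Compound 3 is estimated at 13000 nM, with a range from 4500 nM to 38000 nM.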

Compound 3, half-maximal inhibitory concentration: 19400 nM
Compound 3: the middle estimate sits 1.5-fold (0.17 log units) below what was measured, within the range that was stated.
By their numbers in this assay, from the lowest: compounds 1, 2 and 3 (each within the scatter of the next).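

In this assay, 3-bromophenyl in place of 2-bromophenyl on a nitrogen on an aromatic ring gives a 1.3-fold higher number from compound 2 to compound 3 (0.11 log units; within the scatter) and so does not count as a real difference. Within the data shown here, this is the first direct reading at this position: compound 2 and compound 3 have the same atoms, so the place of the bromine on the ring is the only thing that varies, and these two placements cannot be told apart in this test. No separate measurement is available to bear on this result.

As far as these compounds go, compound 1 has no bromine on this ring but also differs from compound 2 elsewhere, so the two cannot be compared directly, and what the bromine itself contributes stays open. From the compounds shown here alone, it is also open whether a different group on the same ring, such as a methoxy group, an amine or a carboxylic acid, would shift the number by more than the scatter.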